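Amide Substituent Swap: Nitrile to Amino Ester

The compounds below may be only part of what the source reports. "The series", "measured", "known", "first", "only" and "open" are said of these compounds alone.

Compound 1 `CCn1c(C(=O)NCCCN(C)C)ccc1C(CC)(CC)c1ccc(OCCC(O)(CC)CC)c(C)c1` gives 2420 nM in an ADME assay on L02 cells (Homo sapiens) for antiproliferative activity, read by MTT assay, with a stated time of 48 h; a higher number here means a weaker inhibitor, a lower number a stronger inhibitor. Compound 2 `CCn1c(C(=O)NCC#N)ccc1C(CC)(CC)c1ccc(OCCC(O)(CC)CC)c(C)c1` gives > 50000 nM, which is a limit of the assay rather than a number. Compound 2 thus stands at the limit of > 50000 nM in this assay, at which 1 of the 2 values shown sits, and the step of an at least 20-fold higher number from compound 1 to compound 2 (1.31 log units; beyond the scatter) is known only in size as shown. Compound 3 `CCC(C)C(NC(=O)c1ccc(C(CC)(CC)c2ccc(OCCC(O)(CC)CC)c(C)c2)n1CC)C(=O)OC` differs from compound 2 by a group of 9 heavy atoms (7 carbon, 2 oxygen; no ring) in place of a group of 3 heavy atoms (2 carbon, 1 nitrogen; no ring), on an amide-type nitrogen. For the measured compounds named here, the one measured step also alters the group on the amide nitrogen and ends at the limit, so a large further change is not expected. Compound 3 is estimated at 40000 nM, between 10000 nM and 120000 nM. This expected step is an at least 1.2-fold lower number from compound 2 to compound 3 (0.09 log units; that floor lies within the scatter).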

Compound 3, half-maximal inhibitory concentration: > 50000 nM
Compound 3: no number, only a limit (the forecaster's own chance of this, stated with the estimate: 55%); middle value at least 1.2-fold (0.09 log units) from the limit.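

On the amide-type nitrogen, a second group gives only a limit: in this assay, compound 3 gives > 50000 nM, which is a limit of the assay and not a number. The change on this nitrogen gives an at least 20-fold higher number from compound 1 to compound 3 (1.31 log units; beyond the scatter), so the large step is no longer tied to cyanomethyl alone. The step between the two limits cannot be read, and the series now stands as follows: the limit of > 50000 nM in this assay, at which 2 of the 3 values shown sit.

Going by these compounds, whether a carboxylic acid or a primary amine in the group on this nitrogen would bring a value back within the range of the assay stays open. Which part of the group in compound 1 goes with its measured value is also unsettled.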